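This account rests on a few compounds, and the source may have more. Where it says the series, first, only, none or still open, it means among the compounds named here.

In a functional assay on HL-60 cells (Homo sapiens) for cytotoxicity, read by WST assay, with a stated time of 48 h (on this read-out higher numbers stand for an effect only at larger amounts of compound and lower numbers for an effect already at smaller amounts), compound 1 `CCCCOc1ccccc1C[C@H]1COC[C@@H]1Cc1ccc(Cl)c(Cl)c1` gives 20000 nM, and compound 2 `Fc1ccccc1C[C@H]1COC[C@@H]1Cc1ccc(Cl)c(Cl)c1` gives 51000 nM, the higher of the two numbers. Compound 3 `Fc1cccc(C[C@H]2COC[C@@H]2Cc2ccc(Cl)c(Cl)c2)c1` differs from compound 2 as follows: 3-fluorophenyl in place of 2-fluorophenyl on a saturated chain carbon bound to a saturated ring carbon, with 3-fluorophenyl in place of 2-fluorophenyl on a saturated chain carbon bound to a saturated ring carbon. Among the measured compounds shown here, the only measured step, a 2.6-fold higher number from compound 1 to compound 2 (0.41 log units; beyond the scatter), is modest, but it replaces butoxy with fluoro and gives no direct measure of this change. No step beyond the scatter is therefore expected in this assay. The expected step is a 1.1-fold lower number from compound 2 to compound 3 (0.05 log units; within the scatter). Compound 3 is estimated at 45000 nM, with an expected range of 20000 nM to 100000 nM.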

Compound 3, half-maximal effective concentration: 20000 nM
Compound 3: the middle estimate sits 2.3-fold (0.35 log units) above what was measured; the range from low to high includes it.
By their numbers in this assay, from the lowest: compounds 1 and 3 (each within the scatter of the next); then compound 2.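

In this assay, 3-fluorophenyl in place of 2-fluorophenyl on a saturated chain carbon bound to a saturated ring carbon gives a 2.6-fold lower number from compound 2 to compound 3 (0.41 log units; beyond the scatter), so at this place the same atoms, joined differently, change the read-out beyond the scatter. The earlier step exchanged butoxy for fluoro and could not show this. Nothing at hand bears on a cause for this step.
The compounds shown leave open whether an amine or a carboxylic acid in place of the fluoro would keep this number, and whether the step carries over to other substituents on this ring.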